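N-Methylation of a Propargylamine Inhibitor of Amine Oxidase B

The compounds below may be only part of what the source reports. "The series", "measured", "known", "first", "only" and "open" are said of these compounds alone.

Measured compounds, all in an assay on isolated protein for inhibition of Amine oxidase [flavin-containing] B (Rattus norvegicus); a higher number here means a weaker inhibitor, a lower number a stronger inhibitor:
compound 1 `C#CCNCc1cc2ccccc2n1C` gives 3830 nM
compound 2 `C#CCNCc1cc2cc(O)ccc2n1C` gives 8900 nM
compound 3 `CC#CCN(C)Cc1cc2cc(OC)ccc2n1C` gives 370 nM

Compound 1 stands second highest of the three numbers in this assay. Its nearest neighbour is compound 2, reached by a 2.3-fold higher number from compound 1 to compound 2 (0.37 log units; beyond the scatter); the furthest is compound 3, whose number is the lowest of the set, though compound 3 differs from compound 1 in more than one place, so no single step can be read from that pair.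

Compound 4 `C#CCN(C)Cc1cc2ccccc2n1C` is the unmeasured compound. It differs from compound 1 by methyl in place of hydrogen on an amine nitrogen. Within the data shown here, no measured pair shows this change alone: the only single-point step, from compound 1 to compound 2, concerns a hydroxy group on the aromatic ring and says nothing about the amine nitrogen. Among the measured compounds shown here, the one compound that carries a methyl on its amine nitrogen, compound 3, also carries a methoxy group and a longer alkyne, and its value in this assay is the lowest seen; with those other differences the direction is suggestive only. The account therefore expects a lower number for compound 4 than for compound 1, by a step of a 3.5-fold lower number from compound 1 to compound 4 (0.54 log units; beyond the scatter), and estimates compound 4 at 1100 nM, within 300 nM to 3800 nM.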

Compound 4, inhibition constant: 3 nM
Estimate against measurement, compound 4: 370-fold (2.56 log units) above; measured number below the stated range.
By their numbers in this assay, from the lowest: compound 4; then compound 3; then compound 1; then compound 2.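

In this assay, among these compounds, the amine nitrogen turns out to be far more sensitive than the earlier compounds could show: methyl in place of hydrogen there gives a 1300-fold lower number from compound 1 to compound 4 (3.11 log units; beyond the scatter) as a large step, although the entering group has only one carbon, no ring, no hydrogen-bond donor or acceptor and no net charge. Among the compounds shown here, the only single-place step available before, a 2.3-fold higher number from compound 1 to compound 2 (0.37 log units; beyond the scatter) with hydroxy in place of hydrogen on an aromatic carbon, was modest and ran the other way, so it gave no hint of how much this one nitrogen substituent can change the number. Nothing shown here gives a measured reason for the size of the step at the amine nitrogen.

From the compounds shown here alone, whether an ethyl group or a longer chain on the same nitrogen would hold, extend or lose this drop in the number remains open. Also open is whether the methyl would give a step of similar size on the core of compound 2, which carries the hydroxy group, since the methyl step is shown only on the unsubstituted core of compound 1.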